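The compounds below may be only part of what the source reports. "The series", "measured", "known", "first", "only" and "open" are said of these compounds alone.

Measured so far:
compound 1 `CC(/C=N/Nc1ccc([N+](=O)[O-])cc1)=N\NC(=O)c1ccccc1C`; in a functional assay on cells (Splenocyte, Mus musculus, strain BALB/c) for inhibition, read by scintillation counting and thymidine incorporation, with a stated time of 72 h (on this read-out higher numbers stand for weaker inhibition and lower numbers for stronger inhibition), compound 1 gives 6000 nM.
compound 2 `CC(/C=N/Nc1ccc([N+](=O)[O-])cc1)=N\NC(=O)c1cccc(C)c1`; in this assay compound 2 gives > 12000 nM.

The value of compound 2 is a limit of this assay, not a number (the limit of > 12000 nM in this assay, at which 1 of the 2 values shown sits). Within the data shown here, the only measured step, an at least 2.0-fold higher number from compound 1 to compound 2 (0.30 log units; that floor lies within the scatter), moved a methyl group on the phenyl ring and ended at that limit. Compound 3 `CC(/C=N/Nc1ccc([N+](=O)[O-])cc1)=N\NC(=O)c1ccc(Cl)cc1` differs from compound 2 by 4-chlorophenyl in place of 3-methylphenyl on a carbonyl carbon. Among the measured compounds shown here, no measured step covers this exchange, so no step beyond the scatter is expected for a number no higher from compound 2 to compound 3 (the limit leaves the size open). Compound 3 is expected near 12000 nM, between 4000 nM and 36000 nM, quite possibly again only as a limit.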

Compound 3, half-maximal inhibitory concentration: 4200 nM
The estimate for compound 3 lay 2.9-fold (0.46 log units) above the measured number; low and high end bracket the measured number.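

Placing 4-chlorophenyl instead of 3-methylphenyl on the carbonyl carbon gave an at least 2.8-fold lower number from compound 2 to compound 3 (0.45 log units; beyond the scatter), so a change at this position can bring a result back from the limit to a real number. That size is only a floor, as the starting value is a limit and not a number: the limit of > 12000 nM in this assay, at which 1 of the 3 values shown sits. Placing 4-chlorophenyl instead of 2-methylphenyl gave a 1.4-fold lower number from compound 1 to compound 3 (0.15 log units; within the scatter), so these two groups cannot be told apart here.

As far as these compounds go, it remains open whether a phenyl ring is needed at this position at all. Also unknown is how an amine or a carboxylic acid on that ring, or a longer chain in its place, would behave.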